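This account rests on a few compounds, and the source may have more. Where it says the series, first, only, none or still open, it means among the compounds named here.

In an ADME assay on J774 cells (Mus musculus) for cytotoxicity, read by MTT assay, with a stated time of 48 h, tested at 150 ug/mL (on this read-out lower numbers stand for a stronger effect and higher numbers for a weaker effect at the one concentration tested), the three measured compounds gave these values:
compound 1 `O=C(N/N=C/c1ccccc1Cl)c1cnccn1`: 69%
compound 2 `O=C(N/N=C/c1cccc(F)c1)c1cnccn1`: 40%
compound 3 `CCOc1cccc(/C=N/NC(=O)c2cnccn2)c1`: 69%

Compound 1 stands together with compound 3 at the top of these three numbers, with no change between the two beyond the scatter, while compound 2 gives a lower value. Compound 4 `O=C(N/N=C/c1ccccc1O)c1cnccn1` differs from compound 1 in one place: hydroxy in place of chloro on an aromatic carbon. Going by the values given here, only one measured step alters a group on an aromatic carbon, a number 29 percentage points higher from compound 2 to compound 3 (beyond the scatter), and it swaps fluoro for ethoxy rather than chloro for hydroxy. Among the compounds with values here, no measured step exchanges chloro for hydroxy, so the expectation is a step within the scatter, a number 3 percentage points higher from compound 1 to compound 4 (within the scatter). Compound 4 is therefore estimated at 72%, with a range from 52% to 92%.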

Compound 4, a percentage reported as activity, at one concentration (the size of the read-out at that concentration, not a potency): 0%
The estimate for compound 4 lay 72 percentage points above the measured number, and the stated range ends above it.
By their numbers in this assay, from the lowest: compound 4; then compound 2; then compounds 1 and 3 (each within the scatter of the next).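

In this assay, hydroxy in place of chloro on the aromatic carbon ortho to a large group gives a number 69 percentage points lower from compound 1 to compound 4 (beyond the scatter). This position is therefore highly sensitive to the group it carries: exchanging one heavy atom for another, with a hydrogen-bond donor and acceptor entering, changes the read-out far beyond the scatter. Nothing available explains this large step.

From the compounds shown here alone, whether a methoxy group or an amine at this position would give a number close to that of compound 4 remains open. So does whether hydroxy elsewhere on the ring would have a similar effect.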